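The compounds below may be only part of what the source reports. "The series", "measured", "known", "first", "only" and "open" are said of these compounds alone.

- compound 1 `CC1=C[C@@](C)(c2cc(NC(=O)c3ccc(C#N)cn3)ccc2F)N=C(N)O1` gives 2.2
- compound 2 `C[C@@]1(c2cc(NC(=O)c3coc(C(F)F)n3)ccc2F)C=C(CF)OC(N)=N1` gives 2.6

Both compounds were read in a physicochemical assay for lipophilicity, read by HPLC, in phosphate buffer, measured as octanol-water partition, with a stated time of 1 h, at pH 7.4; on this read-out higher numbers stand for higher lipophilicity and lower numbers for lower lipophilicity. Compound 2 at 2.6 stands highest of the two numbers, with compound 1 at 2.2 lower by more than the usual scatter.

Compound 3 `C[C@@]1(c2cc(NC(=O)c3coc(CF)n3)ccc2F)C=C(CF)OC(N)=N1` has not been measured yet. It differs from compound 2 in one place (hydrogen in place of fluoro on a saturated chain carbon bound to an aromatic carbon and a fluorine atom): hydrogen in place of fluoro on a saturated chain carbon bound to an aromatic carbon and a fluorine atom. This turns difluoromethyl into fluoromethyl, and 2-(difluoromethyl)-1,3-oxazol-4-yl into 2-(fluoromethyl)-1,3-oxazol-4-yl.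

Within the data shown here, no measured pair here shows this change, so the expectation rests on the structural change alone and carries real uncertainty. In this assay the expected step of a number 0.40 log units lower from compound 2 to compound 3 (beyond the scatter) is a modest fall, a little beyond the usual scatter. For compound 3 the estimated value is 2.2 with an expected range from 1.9 to 2.5 for four of five such measurements.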

Compound 3, distribution coefficient: 2.2
Compound 3: the middle estimate sits on the measured number at the digits printed; low and high end bracket the measured number.
By their numbers in this assay, from the lowest: compounds 1 and 3 (each within the scatter of the next); then compound 2.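

In this assay, hydrogen in place of fluoro on a saturated chain carbon bound to an aromatic carbon and a fluorine atom, which turns difluoromethyl into fluoromethyl, brings a number 0.40 log units lower from compound 2 to compound 3 (beyond the scatter), a modest step. Among these compounds, compounds 2 and 3 are the only pair here that differ in one place, so this is the one step that can be tied to a single change, with the rest of the two structures held the same; as a single pair, it describes these two compounds and sets no general rule. No measurement here gives a reason for the size or direction of this step.

Going by these compounds, whether the number would keep moving the same way along the series from fluoromethyl to a plain methyl, or move the other way with a trifluoromethyl, stays open. Also open, on these data alone, is how a longer chain such as 2-fluoroethyl, or a different kind of group such as an amine, would read at this same place, and whether the step from difluoromethyl to fluoromethyl would be of similar size on another core.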